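Replacing the 1-methyl-2-oxopiperidin-4-yl group of compound 1

The source may hold more compounds than are shown below. What is called first, only, known or untested is meant among the compounds shown, and "the series" means these compounds.

Among the measured compounds shown here, compound 1 `CN1CCC(c2ccc3c(c2)oc(=O)n3C(=O)NCCCCc2ccccc2)CC1=O` and compound 2 `CC(C)CNC(=O)n1c(=O)oc2cc(C3CCCCN3C)ccc21` are the only compounds measured so far in an ADME assay on a cell-free system (plasma, Mus musculus) for metabolic stability, read by LC-MS, tested at 2 uM; a higher number here means that the compound lasts longer, a lower number that the compound disappears faster. Compound 1 gives 0.6 h as its half-life and compound 2 gives 0.5 h as its half-life, two numbers within the scatter of each other. Compound 3 `CCN1CCN(c2ccc3c(c2)oc(=O)n3C(=O)NCCCCc2ccccc2)CC1` keeps the core of compound 1 but carries 4-ethylpiperazin-1-yl in place of 1-methyl-2-oxopiperidin-4-yl on an aromatic carbon. For the measured compounds named here, no measured pair shows what such an exchange does in this assay, so the expectation rests on the two values alone. No step beyond the scatter is expected in either direction, and the estimated change a 1.2-fold higher number from compound 1 to compound 3 (0.07 log units; within the scatter) stays within it. For compound 3 the expected half-life is 0.7 h with an estimated range from 0.3 h to 1.8 h in this assay.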

Compound 3, half-life: < 0.0834 h
Compound 3 was reported as a limit; the forecaster's own chance of this, stated with the estimate: 5%; middle value at least 8.3-fold (0.92 log units) from the limit.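

In this assay, among the compounds shown here, the group on this aromatic carbon proves able to move the half-life: 4-ethylpiperazin-1-yl in place of 1-methyl-2-oxopiperidin-4-yl gives an at least 7.1-fold lower number from compound 1 to compound 3 (0.85 log units; beyond the scatter), whereas the earlier compounds offered no step in one place at all. Going by these compounds, compound 3 is reported only as a limit, so the full size of this step stays unknown: the limit of < 0.0834 h in this assay, at which 1 of the 3 values shown sits. The exchange alters several things at once, as the ring gains a second nitrogen, loses its carbonyl and carries an ethyl group instead of a methyl group, and this single pair cannot separate them.

On these data alone, it remains open whether a morpholin-4-yl or a piperidin-1-yl group at the same place would behave like 1-methyl-2-oxopiperidin-4-yl or like 4-ethylpiperazin-1-yl. As far as these compounds go, it also remains open whether the same exchange would give a similar step with a shorter chain on the urea nitrogen.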